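Swapping the amide acyl group: tissue distribution of compound 4

This account rests on a few compounds, and the source may have more. Where it says the series, first, only, none or still open, it means among the compounds named here.

Compound 1 `CCn1ncc(-c2nc3c(N[C@H]4CCN(C(=O)C5CC5)C4)ncnc3n2C)c1C` gives 4 L/kg in an ADME assay (Rattus norvegicus, strain Wistar Han) for pharmacokinetics (on this read-out higher numbers stand for wider distribution into tissues and lower numbers for narrower distribution), level with compound 3 `CCn1ncc(-c2nc3c(N4CCC(n5c(=O)[nH]c6ncccc65)CC4)ncnc3n2C)c1C` at 4 L/kg and within the scatter of compound 2 `CCn1ncc(-c2nc3c(N[C@H]4CCN(C(=O)C5CCOCC5)C4)ncnc3n2C)c1C` at 3 L/kg. Compound 4 `CCC(=O)N1CC[C@H](Nc2ncnc3c2nc(-c2cnn(CC)c2C)n3C)C1` differs from compound 1 by a single change: ethyl in place of cyclopropyl on a carbonyl carbon. Within the data shown here, the only measured step touching the same carbonyl carbon is a 1.3-fold lower number from compound 1 to compound 2 (0.12 log units; within the scatter), which stayed inside the scatter despite bringing in a group unlike the ethyl entering here. Nothing among the three measured compounds points to a shift beyond the scatter for this small swap, so the expected step is no change at the digits printed from compound 1 to compound 4 (within the scatter) in this assay. Compound 4 is therefore estimated at 4 L/kg, with a likely range from 2 L/kg to 7 L/kg.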

Compound 4, volume of distribution in the Rattus norvegicus assay: 4 L/kg
Estimate against measurement, compound 4: no gap at the digits printed, and the stated range covers the measured number.
By their numbers in the Rattus norvegicus assay, from the lowest: compounds 2, 1, 3 and 4 (each within the scatter of the next).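

In the Rattus norvegicus assay the step with ethyl in place of cyclopropyl is no change at the digits printed from compound 1 to compound 4 (within the scatter) and the step with ethyl in place of oxan-4-yl is a 1.3-fold higher number from compound 2 to compound 4 (0.12 log units; within the scatter). The carbonyl carbon therefore tolerates an acyl substituent without a ring in this read-out, at least across these three groups. In a physicochemical assay for lipophilicity (on this read-out lower numbers stand for lower lipophilicity and higher numbers for higher lipophilicity), compound 1 gives 1 and compound 4 gives 0.8 (a number 0.20 log units lower from compound 1 to compound 4 (within the scatter)).

As far as these compounds go, whether an amine, a carboxylic acid or a longer chain on this carbonyl carbon would move the distribution remains open. No available evidence explains the flat result.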